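Trifluoromethyl on compound 2: expected effect

The source may hold more compounds than are shown below. What is called first, only, known or untested is meant among the compounds shown, and "the series" means these compounds.

In a functional assay on the whole organism for inhibition, with Rattus norvegicus as the target (on this read-out lower numbers stand for an effect already at smaller amounts and higher numbers for an effect only at larger amounts of compound), compound 2 (`CC(C)c1ccc(OC(C)(Cc2ccccc2)C(=O)O)cc1`) reads > 10 mg/kg, which is a limit of the assay and not a number. Compound 4 (`CC(C)c1ccc(OC(C)(Cc2ccc(C(F)(F)F)cc2)C(=O)O)cc1`) differs from it by trifluoromethyl in place of hydrogen on an aromatic carbon, with trifluoromethyl in place of hydrogen on an aromatic carbon. Compound 3 (`CC(C)c1ccc(OC(C)(Cc2cccc(C(F)(F)F)c2)C(=O)O)cc1`) also carries trifluoromethyl and gives 5 mg/kg. Among the compounds with values here, the measured step of an at least 2.0-fold lower number from compound 2 to compound 3 (0.30 log units; that floor lies within the scatter) is the only one of this exchange, and its floor lies within the scatter. Compound 1 (`CC(C)c1ccc(OC(Cc2ccc(C(F)(F)F)cc2)C(=O)O)cc1`) gives 10 mg/kg in this assay. A step towards a lower number is expected, estimated as an at least 2.0-fold lower number from compound 2 to compound 4 (0.30 log units; that floor lies within the scatter), though its size remains uncertain with only a limit for the starting point. Compound 4 is estimated at 5 mg/kg, with an expected range of 2 mg/kg to 12 mg/kg.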

Compound 4, dose for half-maximal effect: < 5 mg/kg
Compound 4: no number, only a limit; the forecaster's own chance of this, stated with the estimate: 25%; the middle value lies on the limit itself.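

In this assay, trifluoromethyl para to a large group gives an at least 2.0-fold lower number from compound 2 to compound 4 (0.30 log units; that floor lies within the scatter), so this place on the ring now has a step of its own. Methyl in place of hydrogen on the saturated chain carbon, with trifluoromethyl para to a large group already present, gives an at least 2.0-fold lower number from compound 1 to compound 4 (0.30 log units; that floor lies within the scatter). Neither step has an exact size, as compound 4 carries a limit and not a number: the limit of < 5 mg/kg in this assay, at which 1 of the 4 values shown sits.

Open, from the compounds shown here alone, is whether a nitrile in place of trifluoromethyl at this place gives a comparable number in this assay. Also open, going by these compounds, is how an ethyl in place of the added methyl would read.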